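This account rests on a few compounds, and the source may have more. Where it says the series, first, only, none or still open, it means among the compounds named here.

Measured compounds in hand:
compound 1, `CCCCCc1ccc(NS(=O)(=O)c2ccc(N3CCNC3=O)cc2)cc1`, gives 990 nM in a functional assay on HT-29 cells (Homo sapiens) for antiproliferative activity, read by sulforhodamine B assay, with a stated time of 48 h; on this read-out higher numbers stand for weaker inhibition and lower numbers for stronger inhibition
compound 2, `Cc1ccccc1NS(=O)(=O)c1ccc(N2CCNC2=O)cc1`, gives 200 nM in this assay
compound 3, `COc1ccccc1NS(=O)(=O)c1ccc(N2CCNC2=O)cc1`, gives 550 nM in this assay

Compound 3 stands second highest of the three numbers. Its nearest neighbour is compound 1, whose value sits within the scatter of that of compound 3, so no order between the two can be read. The furthest is compound 2: the step of a 2.8-fold higher number from compound 2 to compound 3 (0.44 log units; beyond the scatter) lies beyond the scatter.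

Compound 4, `Cc1cc(C)cc(NS(=O)(=O)c2ccc(N3CCNC3=O)cc2)c1`, has not been measured. Relative to compound 3 the change is 3,5-dimethylphenyl in place of 2-methoxyphenyl on a sulfonamide nitrogen.

Among the measured compounds shown here, only one measured step bears on this: a 2.8-fold higher number from compound 2 to compound 3 (0.44 log units; beyond the scatter), which went up when methoxy replaced methyl. Compound 4 removes the methoxy and carries methyl groups, so part of that step should run back in reverse, giving a lower number in this assay than compound 3. For the measured compounds named here, compound 4 is not a return to compound 2, since it carries a 3,5-dimethylphenyl, and no measured compound carries two methyls, so the size is uncertain and a modest downward step is expected, a 1.8-fold lower number from compound 3 to compound 4 (0.26 log units; within the scatter).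

For compound 4 the expected value in this assay is 300 nM, with a range from 120 nM to 800 nM.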

Compound 4, half-maximal inhibitory concentration: 82 nM
The estimate for compound 4 lay 3.7-fold (0.56 log units) above the measured number, and the stated range ends above it.
By their numbers in this assay, from the lowest: compound 4; then compound 2; then compounds 3 and 1 (each within the scatter of the next).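

In this assay, the aryl group on the sulfonamide nitrogen has more room for improvement than the methyl-to-methoxy comparison showed: 3,5-dimethylphenyl in place of 2-methoxyphenyl gives a much larger change (a 6.7-fold lower number from compound 3 to compound 4 (0.83 log units; beyond the scatter)) than that comparison did. Removing the methoxy is not the whole story, since 3,5-dimethylphenyl also improves on the 2-methylphenyl group (a 2.4-fold lower number from compound 2 to compound 4 (0.39 log units; beyond the scatter)), so compound 4 goes beyond simply recovering the level of compound 2, and the series now has a new lowest number. No supporting data bear on why this change lowers the number.

The step from compound 2 to compound 4 alters both the number of methyl groups and where they sit on the ring, and the compounds shown cannot separate these two changes. On these data alone, it also remains open whether other groups on this ring, such as chlorine, trifluoromethyl, an amine or a carboxylic acid, would follow the direction seen with the methyl groups.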